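Replacing a methylfuran by a methylphenyl on a cyanoacrylamide

This account rests on a few compounds, and the source may have more. Where it says the series, first, only, none or still open, it means among the compounds named here.

Of the compounds shown here, two have been measured in a functional assay on A-431 cells (Homo sapiens) for inhibition, read by MTT assay, with a stated time of 72 h; on this read-out higher numbers stand for weaker inhibition of growth and lower numbers for stronger inhibition of growth. Compound 1 `N#C/C(=C\c1c(F)c(F)c(F)c(F)c1F)C(=O)c1ccc[nH]1` gives 64000 nM in this assay. Compound 2 `COc1ccc(CNC(=O)/C(C#N)=C/c2ccc(C)o2)cc1` gives 58000 nM in this assay, which is the lowest of the two numbers, though the gap to compound 1 lies within the scatter of repeated measurements, so the two cannot be ranked against each other.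

Compound 3 `COc1ccc(CNC(=O)/C(C#N)=C/c2ccc(C)cc2)cc1` has not been measured. It differs from compound 2 in one place: 4-methylphenyl in place of 5-methylfuran-2-yl on a double-bonded chain carbon bound to a double-bonded chain carbon. Among the measured compounds shown here, no measured pair shows the effect of such a change, so nothing in the data says which way the number should move. The step from compound 2 to compound 3 is therefore expected to be small, a 1.0-fold higher number from compound 2 to compound 3 (0.01 log units; within the scatter), with no direction beyond the scatter. Compound 3 is estimated to give 60000 nM in this assay, within a range from 25000 nM to 150000 nM, an expectation resting only on compound 2 with its 58000 nM.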

Compound 3, concentration for 50% growth inhibition: 26000 nM
Compound 3: middle estimate off by 2.3-fold (0.36 log units), on the high side, and the stated range covers the measured number.
By their numbers in this assay, from the lowest: compound 3; then compounds 2 and 1 (each within the scatter of the next).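

The double-bonded chain carbon is a position where the choice of ring can shift the read-out: in this assay, 4-methylphenyl in place of 5-methylfuran-2-yl gives a 2.2-fold lower number from compound 2 to compound 3 (0.35 log units; beyond the scatter) and so moves towards stronger inhibition of growth. The step is modest but lies beyond the scatter, and since the rest of the molecule stays the same, it can be tied to this one change. Nothing available here says why the number moves.

The change swaps a five-membered ring holding an oxygen for a six-membered ring of carbon only, and these compounds cannot separate the ring size from the loss of that oxygen. Also open, as far as these compounds go, is what the methyl contributes, which a plain phenyl, a 4-chlorophenyl or a 4-aminophenyl at this place would help to show.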